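This account rests on a few compounds, and the source may have more. Where it says the series, first, only, none or still open, it means among the compounds named here.

For the measured compounds named here, compound 1 `CC(/C=N/Nc1ccc([N+](=O)[O-])cc1)=N\NC(=O)c1ccc(N)cc1` carries an amino group, and in an ADME assay on J774 cells (Mus musculus, strain BALB/c) for cytotoxicity, read by resazurin assay, with a stated time of 72 h (a higher number here means that more compound is tolerated, a lower number that less compound is tolerated), compound 1 gives 75000 nM, the only number among the values shown. Compound 2 `COc1ccc(C(=O)N/N=C(C)/C=N/Nc2ccc([N+](=O)[O-])cc2)cc1` holds methoxy in place of amino; in this assay compound 2 reaches only a limit, > 100000 nM. The step of an at least 1.3-fold higher number from compound 1 to compound 2 (0.12 log units; that floor lies within the scatter) is therefore bounded by the limit of > 100000 nM in this assay, at which 1 of the 2 values shown sits. Compound 3 `CC(/C=N/Nc1ccc([N+](=O)[O-])cc1)=N\NC(=O)c1ccc(N(C)C)cc1` differs from compound 1 by dimethylamino in place of amino on an aromatic carbon. Going by the values given here, no measured step shares this change, and the single measured step gave only a floor, so compound 3 is expected to show no change at the digits printed from compound 1 to compound 3 (within the scatter), nothing beyond the scatter. Compound 3 is estimated at 75000 nM in this assay, between 35000 nM and 160000 nM.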

Compound 3, half-maximal cytotoxic concentration: > 100000 nM
Compound 3: only a limit was reported; the forecaster's own chance of this, stated with the estimate: 40%; middle value at least 1.3-fold (0.12 log units) away from the limit.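

In this assay, dimethylamino in place of amino gives an at least 1.3-fold higher number from compound 1 to compound 3 (0.12 log units; that floor lies within the scatter), so a second group on this aromatic carbon, after methoxy, also ends in a limit rather than a number. The step between compound 2 and compound 3 cannot be read, and compound 1 alone keeps a number: the limit of > 100000 nM in this assay, at which 2 of the 3 values shown sit.

From the compounds shown here alone, the true values of compound 2 and compound 3 remain open, as does whether a step beyond the scatter exists at this position. A carboxylic acid or diethylamino on this carbon would be untested ground among the compounds shown.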